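Phenylsulfonyl on the ring nitrogen: a repeated step toward compound 4

A few compounds are considered here, and "the series" means these few. Any claim that something is new, unique, unknown or untested is made for them only; others in the source may bear on it.

The set contains four compounds built on a diarylidene ketone with a six-membered non-aromatic ring holding one nitrogen. Compound 1 `O=C1/C(=C/c2cccnc2)CNC/C1=C\c1ccccc1F` carries hydrogen on that nitrogen, and compound 2 `O=C1/C(=C/c2cccnc2)CN(S(=O)(=O)c2ccccc2)C/C1=C\c1ccccc1F` carries phenylsulfonyl there instead; the difference is phenylsulfonyl in place of hydrogen on an amine nitrogen in a ring. In an ADME assay on L02 cells (Homo sapiens) for cytotoxicity, read by MTT assay, with a stated time of 24 h (a higher number here means a weaker inhibitor, a lower number a stronger inhibitor), compound 1 gives 15900 nM and compound 2 gives 15300 nM, so that a 1.0-fold lower number from compound 1 to compound 2 (0.02 log units; within the scatter).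

Compound 3 `O=C1/C(=C/c2ccncc2)CNC/C1=C\c1ccccc1C(F)(F)F` has a different pair of aryl groups; how its core differs from that of compound 1 is not broken down here. In this assay compound 3 gives 13400 nM, and its values and those of compound 1 and compound 2 all lie within the scatter of one another.

Compound 4 `O=C1/C(=C/c2ccncc2)CN(S(=O)(=O)c2ccccc2)C/C1=C\c1ccccc1C(F)(F)F` has not yet been measured. Among the compounds with values here, it relates to compound 3 by phenylsulfonyl in place of hydrogen on an amine nitrogen in a ring, which is the same change as the one from compound 1 to compound 2. Because a 1.0-fold lower number from compound 1 to compound 2 (0.02 log units; within the scatter), the step is expected to be a 1.0-fold lower number from compound 3 to compound 4 (0.01 log units; within the scatter). On that basis compound 4 is estimated at 13000 nM in this assay, with a likely range from 7000 nM to 25000 nM.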

Compound 4, half-maximal inhibitory concentration: 12300 nM
For compound 4 the middle estimate is 1.1-fold (0.02 log units) above the measured one; low and high end bracket the measured number.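

In this assay, phenylsulfonyl in place of hydrogen on an amine nitrogen in a ring gives a 1.1-fold lower number from compound 3 to compound 4 (0.04 log units; within the scatter). Set beside the earlier step, the change carries over from one core to the other with no difference that stands out from the scatter: the same change on two cores in this assay, a 1.0-fold lower number (0.02 log units; within the scatter) from compound 1 to compound 2 and a 1.1-fold lower number (0.04 log units; within the scatter) from compound 3 to compound 4, 1.0-fold (0.02 log units) apart, within the scatter of two such steps. This holds only for the two cores shown, which carry different pairs of aryl groups, and since neither step lies beyond the scatter, the agreement shows that the number stays put on both cores, not that phenylsulfonyl shifts it in a consistent direction.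

The compounds shown leave open whether a different group on that nitrogen, such as methylsulfonyl, acetyl or benzyl, would also leave the number within the scatter. They also leave open whether the same holds on a core whose aryl groups carry something else, such as a methoxy group or a carboxylic acid.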